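The compounds below may be only part of what the source reports. "The series", "measured", "known", "first", "only" and "open" are said of these compounds alone.

Compound 1 `O=C(Nc1cccc2cccnc12)c1ncccn1` gives > 10000 nM as a limit
Compound 2 `Cc1cnc(C(=O)Nc2cccc3ccc(C)nc23)cn1` gives > 10000 nM as a limit
Compound 3 `Cc1ccc2cccc(NC(=O)c3cnccn3)c2n1` gives > 10000 nM as a limit

These results all come from a functional assay on BXPC-3 cells (Homo sapiens) for inhibition, read by MTT assay, with a stated time of 72 h (on this read-out lower numbers stand for stronger inhibition and higher numbers for weaker inhibition), and mark how far the testing reached. Compound 3 stands at > 10000 nM as a limit of the assay and not as a number. Compound 1, compound 2 and compound 3 all share one position, (the limit of > 10000 nM in this assay, at which 3 of the 3 values shown sit), so none of them can be ranked against the others.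

The next compound to be tested is compound 4 `Cc1ccc2cccc(NC(=O)c3ncccn3)c2n1`, which has the same atoms as compound 3, joined differently. The change is pyrimidin-2-yl in place of pyrazin-2-yl on a carbonyl carbon, with pyrimidin-2-yl in place of pyrazin-2-yl on a carbonyl carbon. Only one measured step links two of these compounds, a step that the two limits leave unreadable from compound 2 to compound 3, and it is a different change, hydrogen in place of methyl on an aromatic carbon. It gives no size to carry over. Compound 1 also has pyrimidin-2-yl on its carbonyl carbon and reads > 10000 nM as a limit.

With every measured compound at that limit, no clear step in either direction is expected in this assay. The expected step is a step that the limit leaves unreadable from compound 3 to compound 4 and it rests on limits alone. For compound 4 the estimated value is 15000 nM with an expected range from 7000 nM to 40000 nM and will most likely be reported as a limit again.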

Compound 4, half-maximal inhibitory concentration: > 10000 nM
Compound 4 was reported as a limit; the forecaster's own chance of this, stated with the estimate: 85%; the middle value is on the limit's open side.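

Compound 4 cannot be ranked against compound 1, compound 2 or compound 3 in this assay, so none of the new steps can be read, because all four compounds share one position: the limit of > 10000 nM in this assay, at which 4 of the 4 values shown sit.

The compounds shown leave open how strong each one really is, and whether pyrimidin-2-yl in place of pyrazin-2-yl changes that strength at all.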